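The source may report more compounds than this note shows. Statements on the series, on what has been measured and on what is new or still open speak of the compounds shown alone.

Four close relatives share one core and differ only in the substitution of the outer phenyl ring. Compound 1 `C=C(Br)C(=O)Nc1cccc(/C=C/C(=O)Nc2ccccc2)c1` carries no substituent there, compound 2 `C=C(Br)C(=O)Nc1cccc(/C=C/C(=O)Nc2ccc(OC)cc2)c1` one methoxy group, compound 3 `C=C(Br)C(=O)Nc1cccc(/C=C/C(=O)Nc2cc(OC)cc(OC)c2)c1` two, and compound 4 `C=C(Br)C(=O)Nc1cccc(/C=C/C(=O)Nc2cc(OC)c(OC)c(OC)c2)c1` three. In a functional assay on LoVo cells (Homo sapiens) for inhibition, read by MTT assay, with a stated time of 72 h (on this read-out lower numbers stand for stronger inhibition and higher numbers for weaker inhibition), compound 1 gives 3900 nM, while compound 2 gives 550 nM. Among the measured compounds shown here, the single change between them, (methoxy in place of hydrogen on an aromatic carbon), produced a 7.1-fold lower number from compound 1 to compound 2 (0.85 log units; beyond the scatter). Compound 3 gives 1210 nM in this assay; how the core of compound 3 differs from that of compound 1 is not broken down here, and its number lies between those of compounds 1 and 2. Compound 4 is the only one not yet measured. It differs from compound 3 by methoxy in place of hydrogen on an aromatic carbon, which is the same kind of change as that from compound 1 to compound 2, though here the entering group sits ortho to two methoxy groups as well as para to a large group. Because the earlier step gave a 7.1-fold lower number from compound 1 to compound 2 (0.85 log units; beyond the scatter), a smaller gain is expected here, a 1.9-fold lower number from compound 3 to compound 4 (0.27 log units; within the scatter), since compound 3 already carries two methoxy groups. Compound 4 is therefore estimated at 650 nM, with a plausible range from 200 nM to 2000 nM.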

Compound 4, half-maximal inhibitory concentration: 140 nM
Estimate against measurement, compound 4: 4.6-fold (0.67 log units) above; the whole stated range lies above it.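

In this assay, putting methoxy in place of hydrogen on an aromatic carbon gave an 8.6-fold lower number from compound 3 to compound 4 (0.94 log units; beyond the scatter), so the gain did not shrink on a core that already carried two methoxy groups. Set beside the earlier step, the same change carried over from one core to the other with much the same size: the same change on two cores in this assay, a 7.1-fold lower number (0.85 log units; beyond the scatter) from compound 1 to compound 2 and an 8.6-fold lower number (0.94 log units; beyond the scatter) from compound 3 to compound 4, 1.2-fold (0.09 log units) apart, within the scatter of two such steps. Among the compounds shown here, this is only two steps in a single cell assay, so it shows that the change transferred between these two cores, but not that it would do so on any other core, and it gives no reason for the gain.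

The compounds shown leave open whether methoxy itself matters, or whether a hydroxyl group, a fluorine atom or an amine at the same place on the outer ring would give a similar step. They also leave open whether a longer chain, such as ethoxy, would match methoxy.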